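Chloro in place of methyl on compound 3

This account rests on a few compounds, and the source may have more. Where it says the series, first, only, none or still open, it means among the compounds named here.

Compound 1 `Cc1ccc(S(=O)(=O)Oc2ccccc2/C=C(\C#N)C(=O)Nc2nnc(C)s2)cc1` gives 78% in a functional assay on HL-60 cells (Homo sapiens) for inhibition, read by CCK-8 assay, with a stated time of 48 h, tested at 20 uM (a higher number here means more inhibition of growth at the concentration tested, a lower number less inhibition of growth), and compound 2 `Cc1ccc(S(=O)(=O)Oc2cccc(/C=C(\C#N)C(=O)Nc3nnc(-c4ccccc4)s3)c2)cc1` gives 63% on the same read-out. Compound 3 `COc1ccc(Cc2nnc(NC(=O)/C(C#N)=C/c3ccccc3OS(=O)(=O)c3ccc(C)cc3)s2)cc1` gives 25% and stands lowest of the three numbers. Going by the values given here, the one measured step of a number 53 percentage points lower from compound 1 to compound 3 (beyond the scatter) is large, but it belongs to a different change, 4-methoxyphenyl in place of hydrogen on a saturated chain carbon bound to an aromatic carbon. Compound 4 `COc1ccc(Cc2nnc(NC(=O)/C(C#N)=C/c3ccccc3OS(=O)(=O)c3ccc(Cl)cc3)s2)cc1` carries chloro in place of methyl on an aromatic carbon, para to a large group (chloro in place of methyl on an aromatic carbon). Among the compounds with values here, no measured step covers this change, so no shift beyond the scatter is expected in this assay here. The estimated step of a number 5 percentage points higher from compound 3 to compound 4 (within the scatter) is therefore small. Compound 4 is expected at 30% (estimated range 14% to 52%).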

Compound 4, percent growth inhibition at one concentration: 20%
Estimate against measurement, compound 4: 10 percentage points above; low and high end bracket the measured number.
By their numbers in this assay, from the lowest: compounds 4 and 3 (each within the scatter of the next); then compound 2; then compound 1.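

In this assay, 4-chlorophenyl in place of 4-methylphenyl on the sulfonyl gives a number 5 percentage points lower from compound 3 to compound 4 (within the scatter), so chloro and methyl on this aromatic carbon, para to a large group, cannot be told apart at the concentration tested. Going by these compounds alone, this is the only step read at this place, while the large step of a number 53 percentage points lower from compound 1 to compound 3 (beyond the scatter) belongs to a different change. No supporting measurement bears on this result.

From the compounds shown here alone, whether an amine or a carboxylic acid at this place would move the number stays open. So does whether chloro in place of methyl would read the same with compound 1 at 78% as the starting point.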